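Indole Replaced by tert-Butylphenyl on the Shared Core

This account rests on a few compounds, and the source may have more. Where it says the series, first, only, none or still open, it means among the compounds named here.

Compound 3 `COc1cc(-c2ccnc3cc(-c4cn(C)c5ccccc45)nn23)cc(OC)c1OC` was tested in a functional assay on B16-F0 cells (Mus musculus) for inhibition, read by CCK-8 assay, with a stated time of 48 h (a higher number here means a weaker inhibitor, a lower number a stronger inhibitor), where compound 3 gives 185 nM. Among the three measured compounds it holds the second highest number: compound 1 `COc1cc(-c2ccnc3cc(-c4cn(CO)c5ccccc45)nn23)cc(OC)c1OC` gives 93 nM, and compound 2 `Cn1ccc2cc(-c3cc4nccc(-c5ccc(F)cc5)n4n3)ccc21` gives 4780 nM. Among the compounds with values here, the only single-place step recorded, a 2.0-fold higher number from compound 1 to compound 3 (0.30 log units; within the scatter), concerns hydrogen in place of hydroxy on a saturated chain carbon bound to an aromatic nitrogen and lies within the scatter. Compound 4 `COc1cc(-c2ccnc3cc(-c4ccc(C(C)(C)C)cc4)nn23)cc(OC)c1OC` is not yet measured; it differs from compound 3 by 4-(tert-butyl)phenyl in place of 1-methyl-1H-indol-3-yl on an aromatic carbon. Within the data shown here, no measured step bears directly on this change: the one recorded step alters a different part of the molecule, and compound 2 differs from compound 3 in more than one place, so its much higher number cannot be assigned to any single change. Among the measured compounds shown here, with no guiding step, the expectation for compound 4 is a moderate weakening, a 3.2-fold higher number from compound 3 to compound 4 (0.51 log units; beyond the scatter), carrying a wide range. In this assay compound 4 is estimated at 600 nM, between 150 nM and 2500 nM.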

Compound 4, half-maximal inhibitory concentration: > 10000 nM
Compound 4 was reported as a limit; the forecaster's own chance of this, stated with the estimate: 5%; at least 16-fold (1.22 log units) between middle value and limit.
By their numbers in this assay, from the lowest: compounds 1 and 3 (each within the scatter of the next); then compound 2. At a limit, above all of these: compound 4.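

In this assay, compound 4 is reported only as a limit, > 10000 nM. Within the data shown here, putting 4-(tert-butyl)phenyl in place of 1-methyl-1H-indol-3-yl on this aromatic carbon of the five-membered aromatic ring gives an at least 54-fold higher number from compound 3 to compound 4 (1.73 log units; beyond the scatter), so this position, unlike the hydroxy change in the one earlier step, carries a large change, even though the group leaving and the group entering have the same count of heavy atoms. The full size of this step cannot be read, because it rests on a limit: the limit of > 10000 nM in this assay, at which 1 of the 4 values shown sits.

What the compounds shown leave open is whether the step follows from losing the indole or from gaining the tert-butyl group. A plain phenyl, or a phenyl carrying an amine in place of tert-butyl, at this carbon would separate the two.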